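Rearranging the Side Chain of Compound 2

A few compounds are considered here, and "the series" means these few. Any claim that something is new, unique, unknown or untested is made for them only; others in the source may bear on it.

In an ADME assay on HeLa cells (Homo sapiens) for cytotoxicity (a lower number here means that less compound is tolerated, a higher number that more compound is tolerated), compound 1 (`O=C(NCC1CCCCC1)c1nc(-c2ccccn2)nc(O)c1O`) gives 3600 nM, and compound 2 (`O=C(NCCC1CCCCC1)c1nc(-c2ccccn2)nc(O)c1O`) gives 4200 nM. Among the compounds with values here, compound 2 therefore holds the higher of only two numbers, although the two lie within the usual scatter of each other.

Compound 3 (`C[C@@H](NC(=O)c1nc(-c2ccccn2)nc(O)c1O)C1CCCCC1`) has the same atoms as compound 2, joined differently: 1-cyclohexylethyl in place of 2-cyclohexylethyl on an amide-type nitrogen. On the amide-type nitrogen, 1-cyclohexylethyl stands in place of 2-cyclohexylethyl, and the new group has 1 defined stereocentre.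

Within the data shown here, one measured step bears on this change, and only loosely: a 1.2-fold higher number from compound 1 to compound 2 (0.07 log units; within the scatter). It concerns the same side chain, but neither measured compound has a 1-cyclohexylethyl group, so the data give no direction. The expected change is therefore none beyond the scatter, with an estimated 1.1-fold lower number from compound 2 to compound 3 (0.02 log units; within the scatter). For compound 3, the estimated value is 4000 nM, within an expected range of 1800 nM to 9000 nM.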

Compound 3, half-maximal cytotoxic concentration: 3200 nM
Estimate against measurement, compound 3: 1.3-fold (0.10 log units) above; low and high end bracket the measured number.
By their numbers in this assay, from the lowest: compounds 3, 1 and 2 (each within the scatter of the next).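

In this assay, the cyclohexyl ring can sit on a branched chain as well as on a straight one without a change beyond the scatter: 1-cyclohexylethyl in place of 2-cyclohexylethyl on the amide-type nitrogen gives (a 1.3-fold lower number from compound 2 to compound 3 (0.12 log units; within the scatter)). Methyl in place of hydrogen on the chain carbon bound to that nitrogen and to the ring also stays within the scatter (a 1.1-fold lower number from compound 1 to compound 3 (0.05 log units; within the scatter)), so neither change separates compound 3 from compound 1 or compound 2. Nothing at hand explains these results.

On these data alone, whether the opposite arrangement at the defined stereocentre of 1-cyclohexylethyl would give a similar number remains open. So does the effect of an amine or a carboxylic acid on this side chain.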